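A few compounds are considered here, and "the series" means these few. Any claim that something is new, unique, unknown or untested is made for them only; others in the source may bear on it.

Measured so far:
compound 1 `Cc1ccc(Oc2cccc(COc3ccccc3CCC(=O)OC[C@H]3OCCC[C@H]3OP(=O)(O)OC[C@H](N)C(=O)O)c2)cc1`: "not active" (no number reported)
compound 2 `N[C@@H](COP(=O)(O)O[C@@H]1CCCO[C@@H]1COC(=O)CCc1ccc(OCc2cccc(Oc3ccccc3)c2)cc1)C(=O)O`: "not active" (no number reported)
compound 3 `CCCCCCCCCCCOc1ccccc1CCC(=O)OC[C@H]1OCC=C[C@H]1OP(=O)(O)OC[C@H](N)C(=O)O`: 12.4%

In an assay on HEK293-A cells for agonist activity at putative P2Y purinoceptor 10 (Mus musculus), with a stated time of 1.5 h (a lower number here means a smaller maximal response, a higher number a larger maximal response), compound 1 gives "not active" (no number reported), so no single number stands for it; compound 2 is the one further entry without a single number, and only compound 3, which in this assay reaches 12.4%, carries a value. Compound 4 `N[C@@H](COP(=O)(O)O[C@@H]1CCCO[C@@H]1COC(=O)CCc1ccccc1OCc1cccc(Oc2ccc(Cl)cc2)c1)C(=O)O` is not yet measured. It differs from compound 1 in one place: chloro in place of methyl on an aromatic carbon. Read one bond further out, this is 4-methylphenoxy to 4-chlorophenoxy, sitting para to a large group. For the measured compounds named here, no step between measured compounds is available to scale such a change. With compound 1 without a number, any step in this assay is expected to be small, at most a modest rise, and likely not beyond the scatter. Compound 4 is therefore expected to reach about 8% in this assay, within 0% to 22%.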

Compound 4, largest response reached (Emax), in percent of the reference or control that the assay uses: "not active" (no number reported)
For compound 4 the study gives words and no number, and the estimate cannot be compared.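

For the compounds shown here, compound 1 and compound 4 both carry words without a number, so no step from methyl to chloro can be read. The compounds shown leave open whether that swap alters the maximal response at all. No supporting evidence bears on this result.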